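The source may report more compounds than this note shows. Statements on the series, on what has been measured and on what is new or still open speak of the compounds shown alone.

In a functional assay on WIL2-NS cells (Homo sapiens) (a lower number here means a stronger inhibitor, a higher number a weaker inhibitor), compound 2 `O=C(O)c1nn([C@@H]2O[C@H](CO)[C@@H](O)[C@H]2O)cc1I` gives > 300000 nM, which is a limit and not a number. Compound 1 `NC(=O)c1nn([C@@H]2O[C@H](CO)[C@@H](O)[C@H]2O)cc1I` gives > 300000 nM, also a limit. Compound 2 therefore has no measured potency to start from, and the record so far is the limit of > 300000 nM in this assay, at which 2 of the 2 values shown sit. The next change puts 3-methyl-1,2,4-oxadiazol-5-yl in place of carboxy on an aromatic carbon, giving compound 3 `Cc1noc(-c2nn([C@@H]3O[C@H](CO)[C@@H](O)[C@H]3O)cc2I)n1`: 3-methyl-1,2,4-oxadiazol-5-yl in place of carboxy on an aromatic carbon. Among the compounds with values here, the only measured step bearing on this position, hydroxy in place of amino on a carbonyl carbon, is a step that the two limits leave unreadable from compound 1 to compound 2, so it offers no size to carry over. Neither replacement of this group has yet produced a readable value, so compound 3 is expected to remain at or near the limit in this assay. The estimated change is an at least 1.5-fold lower number from compound 2 to compound 3 (0.17 log units; that floor lies within the scatter), with any readable shift expected towards stronger inhibition. Compound 3 is estimated at 200000 nM, within an expected range of 50000 nM to 300000 nM.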

Compound 3, half-maximal inhibitory concentration: 3500 nM
Beside the measured number, compound 3's estimate is 57-fold (1.76 log units) above it; the whole stated range lies above it.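

In this assay, this position can carry a readable potency, which neither earlier compound showed: 3-methyl-1,2,4-oxadiazol-5-yl in place of carboxy gives an at least 85-fold lower number from compound 2 to compound 3 (1.93 log units; beyond the scatter) and the same group in place of carbamoyl gives an at least 85-fold lower number from compound 1 to compound 3 (1.93 log units; beyond the scatter) on the same carbon. Both steps start from a limit and so give only a minimum size, while the step from compound 1 to compound 2 cannot be read, leaving carboxy and carbamoyl unranked. Compound 3 is the only one of the three with a number, and the other two remain at the limit: the limit of > 300000 nM in this assay, at which 2 of the 3 values shown sit.

What the compounds leave open is which part of the new group carries the step, the five-membered aromatic ring or its methyl. Also open, going by these compounds, is whether a longer chain in place of that methyl, or an amine on the same carbon, would give a readable value.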